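Two Anilino Analogues Measured, a Third Awaited

The source may hold more compounds than are shown below. What is called first, only, known or untested is meant among the compounds shown, and "the series" means these compounds.

Compound 1 `Cc1nc(Nc2ccc(Cl)c(Cl)c2)sc1C(=O)/C=C/c1ccccc1` was tested in a functional assay on PC-3 cells (Homo sapiens) for cytotoxicity, read by MTT assay (on this read-out higher numbers stand for weaker inhibition and lower numbers for stronger inhibition), and gives 7990 nM. Compound 2 `Cc1nc(Nc2ccccc2)sc1C(=O)/C=C/c1ccccc1` differs from it by phenyl in place of 3,4-dichlorophenyl on a nitrogen on an aromatic ring. For compound 2 this assay reports only a limit, > 25000 nM, which is the limit of > 25000 nM in this assay, at which 1 of the 3 values shown sits. The change produced an at least 3.1-fold higher number from compound 1 to compound 2 (0.49 log units; beyond the scatter).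

Compound 3 `COc1cc(/C=C/C(=O)c2sc(Nc3ccc(Cl)c(Cl)c3)nc2C)cc(OC)c1OC` carries a different core; how it differs from the core of compound 1 is not broken down here. In this assay compound 3 gives 19300 nM, the highest of the two numbers read, with compound 1 the nearest and beyond the scatter.

Compound 4 `COc1cc(/C=C/C(=O)c2sc(Nc3ccccc3)nc2C)cc(OC)c1OC` is the counterpart of compound 3, differing by phenyl in place of 3,4-dichlorophenyl on a nitrogen on an aromatic ring, the same change at the same place as between compound 1 and compound 2. Compound 3 already stands high in this assay, so the earlier step suggests compound 4 will move out of the measurable range. The step expected is a 3.1-fold higher number from compound 3 to compound 4 (0.49 log units; beyond the scatter), resting on the measured step of an at least 3.1-fold higher number from compound 1 to compound 2 (0.49 log units; beyond the scatter). Compound 4 is therefore estimated at 60000 nM, most likely reported only as a limit, with a range from 25000 nM to 150000 nM.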

Compound 4, half-maximal inhibitory concentration: > 25000 nM
Compound 4 gave a limit, no number (the forecaster's own chance of this, stated with the estimate: 85%); the middle value is on the limit's open side.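

In this assay compound 4 is reported only as a limit, > 25000 nM. As far as these compounds go, on the core of compound 3, phenyl in place of 3,4-dichlorophenyl gives an at least 1.2-fold higher number from compound 3 to compound 4 (0.11 log units; that floor lies within the scatter), so this pair runs in the same direction as the earlier one but does not by itself show a change beyond the scatter, and the true size of the step on this core remains unknown. The result therefore shows no conflict between the two cores, yet it does not show that the change carries over with the same size: the same change on two cores in this assay, an at least 3.1-fold higher number (0.49 log units; beyond the scatter) from compound 1 to compound 2 and an at least 1.2-fold higher number (0.11 log units; that floor lies within the scatter) from compound 3 to compound 4; the limit leaves it open whether they differ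

The compounds shown leave open how the series would respond if the anilino phenyl carried a single chlorine, a nitrile or an amine instead of the two chlorines. They also leave open whether the step would hold on any core beyond these two, and where compound 2 and compound 4 would fall on a scale that reaches past the limit.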